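Thioether series: compound 1 to compound 4

The compounds below may be only part of what the source reports. "The series", "measured", "known", "first", "only" and "open" are said of these compounds alone.

Of the compounds shown here, three of the shared core have been tested in an ADME assay on isolated protein for inhibition of Amine oxidase [flavin-containing] B (Homo sapiens); on this read-out higher numbers stand for weaker inhibition and lower numbers for stronger inhibition. Compound 1 `C#CCNC1CCc2c(SCc3cccc(F)c3)cccc21` gives 11600 nM in this assay, the highest number of the three and thus the weakest inhibition. Compound 2 `C#CCNC1CCc2c(SCCc3cccc(Br)c3)cccc21` gives 620 nM in this assay, and compound 3 `C#CCNC1CCc2c(SCc3ccc(Cl)c(Cl)c3)cccc21` gives 74 nM in this assay. Compound 1 stands well apart from both: its gap to compound 2 and its larger gap to compound 3 are each beyond the scatter of repeated measurements. No pair among these three differs in a single place, so no measured step isolates one structural change.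

Compound 4 `C#CCNC1CCc2c(SCc3ccc(C)cc3)cccc21` has not been measured in this assay. Compared with compound 1 the change is 4-methylphenyl in place of 3-fluorophenyl on a saturated chain carbon bound to a sulfur. Among the measured compounds shown here, there is no measured step for this change anywhere in the set, and compound 2 and compound 3 differ from compound 1 in more than one place, so they give only an indication of the range this assay spans for such aryl variations. The step from compound 1 to compound 4 is expected to be a 2.9-fold lower number from compound 1 to compound 4 (0.46 log units; beyond the scatter), a moderate move toward stronger inhibition, though the data would also allow no change beyond the scatter. Compound 4 is estimated at 4000 nM in this assay, within a range from 800 nM to 20000 nM.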

Compound 4, half-maximal inhibitory concentration: 320 nM
The estimate for compound 4 lay 13-fold (1.10 log units) above the measured number; measured number outside the range, below it.
By their numbers in this assay, from the lowest: compound 3; then compounds 4 and 2 (each within the scatter of the next); then compound 1.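

In this assay, 4-methylphenyl in place of 3-fluorophenyl on a saturated chain carbon bound to a sulfur gives a 36-fold lower number from compound 1 to compound 4 (1.56 log units; beyond the scatter), a large move toward stronger inhibition. Among the compounds shown here, this is the first step that isolates one structural change, and it shows that the aryl group at this position can alone move the read-out by a large amount, which compounds 1, 2 and 3 could not show because they differ from one another in more than one place. For the compounds shown here, nothing measured so far accounts for the size of this step.

On these data alone, the step replaces the fluorine with a methyl and also changes the printed ring number, so it remains open whether the gain belongs to the loss of fluorine, the presence of methyl or the ring number of the group. Plain phenyl, 3-methylphenyl and 4-fluorophenyl at this position would separate these possibilities, while a 4-methoxyphenyl or 4-carboxyphenyl group would test how far the trend extends.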